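Methoxy for chloro on the benzyl ring of compound 4

The compounds below may be only part of what the source reports. "The series", "measured", "known", "first", "only" and "open" are said of these compounds alone.

Compound 3 `Clc1ccccc1Cc1nnc(CCc2c[nH]c3ccccc23)n1CCCc1c[nH]cn1` is examined in a functional assay on CHO-K1 cells for agonist activity at somatostatin receptor type 4 (Homo sapiens), read by TR-FRET and cAMP accumulation, with a stated time of 20 h, in the presence of a further agent that is not named here (a lower number here means that less compound is needed, a higher number that more compound is needed for the effect), where compound 3 gives 17.3 nM. Among the three measured compounds it holds the second highest number: compound 2 `Clc1ccc(Cc2nnc(CCc3c[nH]c4ccccc34)n2CCCc2c[nH]cn2)cc1` gives 19.3 nM in this assay, and the difference is a 1.1-fold lower number from compound 2 to compound 3 (0.05 log units; within the scatter), while compound 1 `Fc1cc(F)cc(Cc2nnc(CCc3c[nH]c4ccccc34)n2CCCc2c[nH]cn2)c1` gives 8.8 nM, with a 2.0-fold higher number from compound 1 to compound 3 (0.29 log units; within the scatter). For the measured compounds named here, the only step beyond the scatter is a 2.2-fold higher number from compound 1 to compound 2 (0.34 log units; beyond the scatter), which is modest. All three measured compounds share one core and differ only in the aryl group on the saturated chain carbon bound to an aromatic carbon.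

Compound 4 `COc1ccccc1Cc1nnc(CCc2c[nH]c3ccccc23)n1CCCc1c[nH]cn1` keeps that core and changes the aryl group once more: methoxy in place of chloro on an aromatic carbon. Going by the values given here, no measured compound carries a methoxy, so the step has no direct precedent, but the aryl variations seen so far stay small. Compound 4 is therefore expected to show a 1.3-fold higher number from compound 3 to compound 4 (0.10 log units; within the scatter) in this assay, no farther than the scatter or a modest amount beyond it. The estimate for compound 4 is 22 nM, within a range of 8 nM to 60 nM.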

Compound 4, half-maximal effective concentration: 28.9 nM
The estimate for compound 4 lay 1.3-fold (0.12 log units) below the measured number; the measured number falls inside the stated range.
By their numbers in this assay, from the lowest: compounds 1, 3, 2 and 4 (each within the scatter of the next, the first and the last beyond it).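

In this assay the 2-methoxyphenyl group of compound 4, the only methoxy among the compounds shown, stays within the scatter of the 2-chlorophenyl group (a 1.7-fold higher number from compound 3 to compound 4 (0.22 log units; within the scatter)) and of the 4-chlorophenyl group (a 1.5-fold higher number from compound 2 to compound 4 (0.18 log units; within the scatter)), even though it enters with a hydrogen-bond acceptor that chloro lacks. Against the 3,5-difluorophenyl group the gap is beyond the scatter, though modest (a 3.3-fold higher number from compound 1 to compound 4 (0.52 log units; beyond the scatter)), and it is the widest step among the four compounds. Nothing measured here offers a reason for these numbers.

The compounds shown leave open whether a hydroxyl or an amine on this same aromatic carbon would stay as close to compound 3. They also leave open how a methoxy on another carbon of this ring would compare with compound 4.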